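The source may hold more compounds than are shown below. What is called first, only, known or untested is meant among the compounds shown, and "the series" means these compounds.

In a functional assay on SK-OV-3 cells (Homo sapiens) for antiproliferative activity (a higher number here means a weaker inhibitor of growth, a lower number a stronger inhibitor of growth), compound 1 `c1ccc(-c2cc(-c3ccsc3)cc(-c3ccccn3)n2)nc1` gives 0.1 ug/mL, the lowest of the three numbers measured. For the measured compounds named here, compound 2 `c1ccc(-c2cc(-c3cccs3)cc(-c3ccncc3)n2)nc1` gives 48.3 ug/mL and compound 3 `c1ccc(-c2cc(-c3cccs3)cc(-c3cccnc3)n2)nc1` gives 52 ug/mL; the step of a 1.1-fold higher number from compound 2 to compound 3 (0.03 log units; within the scatter) is the only single-point change among the measured compounds. Compound 4 `c1ccc(-c2cc(-c3ccco3)cc(-c3ccccn3)n2)nc1` has not been measured. It differs from compound 1 in one place: furan-2-yl in place of thiophen-3-yl on an aromatic carbon. Going by the values given here, no measured step touches that five-membered ring; compounds 2 and 3 carry thiophen-2-yl, but each also differs from compound 1 elsewhere, so their gap to compound 1 cannot be assigned to either change. The expected step is therefore a 2.0-fold higher number from compound 1 to compound 4 (0.30 log units; within the scatter), a modest shift at best. Compound 4 is thus expected to give 0.2 ug/mL, with a range from 0.05 ug/mL to 1 ug/mL.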

Compound 4, concentration for 50% growth inhibition: 0.13 ug/mL
Compound 4: middle estimate off by 1.5-fold (0.19 log units), on the high side, and the stated range covers the measured number.
By their numbers in this assay, from the lowest: compounds 1 and 4 (each within the scatter of the next); then compounds 2 and 3 (each within the scatter of the next).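

In this assay, furan-2-yl takes the place of thiophen-3-yl opposite the ring nitrogen with a 1.3-fold higher number from compound 1 to compound 4 (0.11 log units; within the scatter) and so leaves the number unchanged within the scatter. For the compounds shown here, this is the first measured step at this position, and it shows that the position accepts one five-membered aromatic ring with oxygen as readily as another with sulfur. Going by these compounds alone, the single step changes both the hetero atom and the point of attachment, so their separate contributions remain unresolved, as does the outcome with a phenyl ring or an aminomethyl group here. No available evidence bears on why these two rings give such close numbers.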